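Fluorophenyl Sulfonamides on a Quinazoline Core: Predicting Compound 4

The source may report more compounds than this note shows. Statements on the series, on what has been measured and on what is new or still open speak of the compounds shown alone.

Measured compounds:
Compound 1 `COc1ncc(-c2ccc3ncnc(NCCN(C)C)c3c2)cc1NS(C)(=O)=O`: 4120 nM
Compound 2 `COc1ncc(-c2ccc3ncnc(NCCN(C)C)c3c2)cc1NS(=O)(=O)c1ccc(F)cc1`: 2420 nM
Compound 3 `CCCCS(=O)(=O)Nc1cc(-c2ccc3ncnc(NCc4ccncc4)c3c2)cnc1OC`: 9420 nM

In a functional assay on A549 cells (Homo sapiens) for antiproliferative activity, read by sulforhodamine B assay, with a stated time of 72 h (on this read-out lower numbers stand for stronger inhibition and higher numbers for weaker inhibition), compound 1 gives 4120 nM, the second highest number of the three. Compound 2, its nearest neighbour, differs by a 1.7-fold lower number from compound 1 to compound 2 (0.23 log units; within the scatter), which lies within the scatter; compound 3 stands furthest away with 9420 nM, beyond the scatter from compound 1 on the weaker side.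

Compound 4 `COc1ncc(-c2ccc3ncnc(NCCN(C)C)c3c2)cc1NS(=O)(=O)c1ccc(F)cc1F` is not yet measured. It differs from compound 1 as follows: 2,4-difluorophenyl in place of methyl on a sulfonyl sulfur. Among the compounds with values here, the only step that bears on this change is a 1.7-fold lower number from compound 1 to compound 2 (0.23 log units; within the scatter), which was within the scatter; a second fluorine on the same ring is therefore not expected to move the number beyond the scatter either. For compound 4 the estimate is 2600 nM (range 1000 nM to 6500 nM), a step of a 1.6-fold lower number from compound 1 to compound 4 (0.20 log units; within the scatter) that is expected to stay within the scatter.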

Compound 4, half-maximal inhibitory concentration: 940 nM
The estimate for compound 4 lay 2.8-fold (0.44 log units) above the measured number, outside the stated range (below it).
By their numbers in this assay, from the lowest: compound 4; then compounds 2 and 1 (each within the scatter of the next); then compound 3.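

In this assay, 2,4-difluorophenyl in place of methyl on the sulfonyl sulfur gives a 4.4-fold lower number from compound 1 to compound 4 (0.64 log units; beyond the scatter), a step beyond the scatter, which the 4-fluorophenyl group of compound 2 did not reach from compound 1. The second fluoro, in place of hydrogen on an aromatic carbon, gives a 2.6-fold lower number from compound 2 to compound 4 (0.41 log units; beyond the scatter), so one added fluorine on this ring moves the number beyond the scatter. Nothing available explains this gain.

As far as these compounds go, whether a chloro group in place of the second fluoro would give a similar step remains open. So does whether the gain would hold with a morpholine in place of the dimethylamino group.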